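This account rests on a few compounds, and the source may have more. Where it says the series, first, only, none or still open, it means among the compounds named here.

Compound 1, `Nc1cc(N)c2nc(-c3ccccc3)c(NCc3ccc(Cl)c(Cl)c3)nc2c1`, gives 19500 nM in a functional assay on T47D cells (Homo sapiens) for inhibition, read by sulforhodamine B assay, with a stated time of 48 h; a higher number here means a weaker inhibitor of growth, a lower number a stronger inhibitor of growth. Compound 2, `COc1ccc(CNc2nc3cc(N)cc(N)c3nc2-c2ccccc2)cc1OC`, gives 4470 nM in this assay. Compound 3, `CCOC(=O)[C@H](CCC(=O)O)NC(=O)c1ccc(Sc2nc3cc(N)cc(N)c3nc2-c2ccccc2)cc1`, gives 28800 nM in this assay.

Compound 2 stands lowest of the three numbers; the nearest measured step, a 4.4-fold lower number from compound 1 to compound 2 (0.64 log units; beyond the scatter), lies beyond the scatter, and compound 3 sits further away still. Compound 4, `COc1ccc(CNc2nc3cc(N)cc(N)c3nc2-c2ccccc2)cc1`, differs from compound 2 by hydrogen in place of methoxy on an aromatic carbon. Among the measured compounds shown here, the one step that bears on this change, a 4.4-fold lower number from compound 1 to compound 2 (0.64 log units; beyond the scatter), altered both ring substituents together, so it offers no clean reading for the loss of a single methoxy. Compound 4 is therefore expected to shift little, at most modestly toward a higher number, with a 1.3-fold higher number from compound 2 to compound 4 (0.13 log units; within the scatter). The estimate for compound 4 in this assay is 6000 nM, within 2500 nM to 15000 nM.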

Compound 4, concentration for 50% growth inhibition: 2820 nM
The estimate for compound 4 lay 2.1-fold (0.33 log units) above the measured number; the measured number falls inside the stated range.
By their numbers in this assay, from the lowest: compounds 4 and 2 (each within the scatter of the next); then compounds 1 and 3 (each within the scatter of the next).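

In this assay the change from 3,4-dimethoxyphenyl to 4-methoxyphenyl gives a 1.6-fold lower number from compound 2 to compound 4 (0.20 log units; within the scatter) and so leaves the number unchanged within the scatter. The step from the 3,4-dichlorophenyl group gives a 6.9-fold lower number from compound 1 to compound 4 (0.84 log units; beyond the scatter) and shows that a single methoxy carries a step beyond the scatter, as the two methoxy groups of compound 2 did. No measurement shown here explains either step. On these data alone, what remains open is whether the remaining methoxy is needed at all, since hydrogen, hydroxyl or an amine in its place could give a different number.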